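The source may hold more compounds than are shown below. What is called first, only, known or untested is meant among the compounds shown, and "the series" means these compounds.

In a functional assay on A549 cells (Homo sapiens) for antiproliferative activity, read by MTT assay, with a stated time of 72 h (a lower number here means a stronger inhibitor, a higher number a weaker inhibitor), compound 2 `O=C(N/N=C/c1ccc(F)cc1Cl)Nc1ccc(Oc2ccnc3[nH]ccc23)c(F)c1` gives 10 nM, the lower of the two numbers available, while compound 1 `O=C(N/N=C/c1cccc(Br)c1)Nc1ccc(Oc2ccnc3[nH]ccc23)c(F)c1` gives 2220 nM. Compound 3 `COc1ccc(/C=N/NC(=O)Nc2ccc(Oc3ccnc4[nH]ccc34)c(F)c2)cc1` changes the same place on a carbon with a double bond to nitrogen: 4-methoxyphenyl in place of 2-chloro-4-fluorophenyl on a carbon with a double bond to nitrogen. For the measured compounds named here, the only measured step bearing on this is a 220-fold lower number from compound 1 to compound 2 (2.35 log units; beyond the scatter), a large step that shows how strongly this assay can respond to an exchange at this place. Going by the values given here, no measured compound carries the 4-methoxyphenyl group, so a sizeable move towards a higher number is expected, with wide uncertainty. The expected step is a 25-fold higher number from compound 2 to compound 3 (1.40 log units; beyond the scatter). For compound 3, the estimated value is 250 nM, with an expected range from 30 nM to 2500 nM.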

Compound 3, half-maximal inhibitory concentration: 3980 nM
Compound 3: the middle estimate sits 16-fold (1.20 log units) below what was measured, and the stated range ends below it.
By their numbers in this assay, from the lowest: compound 2; then compounds 1 and 3 (each within the scatter of the next).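

In this assay the exchange at this place gives a 400-fold higher number from compound 2 to compound 3 (2.60 log units; beyond the scatter), so the low number of compound 2 does not carry over to the 4-methoxyphenyl group. The other new step, a 1.8-fold higher number from compound 1 to compound 3 (0.25 log units; within the scatter), lies within the scatter, so among these three compounds only the 2-chloro-4-fluorophenyl group stands apart. Nothing available explains this difference. On these data alone, whether the low number needs both the chlorine and the fluorine remains open. So does how this assay would respond to an amine or a carboxylic acid on this ring.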